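The compounds below may be only part of what the source reports. "The series", "measured", "known", "first", "only" and "open" are said of these compounds alone.

Notes on the series. For the measured compounds named here, in an assay on HEK293 cells for displacement of a labelled ligand from Orexin receptor type 2 (Homo sapiens), read by scintillation counting, with a stated time of 90 min (a lower number here means a stronger inhibitor, a higher number a weaker inhibitor), compound 2 `COc1cc(F)c(CN2C(=O)N(c3cnc(OC)c(OC)c3)S(=O)(=O)c3ccccc32)c(F)c1` gives 0.398 nM, the lowest of the three numbers measured so far. Compound 1 `COc1ccc(N2C(=O)N(Cc3c(F)cc(F)cc3OC)c3ccccc3S2(=O)=O)cc1OC` gives 6.31 nM and compound 3 `COc1ccc(N2C(=O)N(Cc3ccccc3)c3ccccc3S2(=O)=O)cc1OC` gives 79.4 nM; both gaps from compound 2 lie beyond the scatter. Going by the values given here, the only single-point step measured to date is a 13-fold higher number from compound 1 to compound 3 (1.10 log units; beyond the scatter), in which phenyl in place of 2,4-difluoro-6-methoxyphenyl on a saturated chain carbon bound to an amide-type nitrogen in a ring brings a large loss. Compound 4 `COc1cc(N2C(=O)N(Cc3c(F)cc(F)cc3Cl)c3ccccc3S2(=O)=O)cnc1OC` differs from compound 2 by 2-chloro-4,6-difluorophenyl in place of 2,6-difluoro-4-methoxyphenyl on a saturated chain carbon bound to an amide-type nitrogen in a ring. That measured step removes every substituent from the ring at this place, whereas the change to compound 4 exchanges one substituted ring for another substituted ring, so the step from compound 1 to compound 3 bears on it only loosely. A movement well short of that step is expected in this assay, if anything toward a higher number, and possibly within the scatter. Compound 4 is therefore expected to give about 1 nM, between 0.3 nM and 4 nM, which is an expected step of a 2.5-fold higher number from compound 2 to compound 4 (0.40 log units; beyond the scatter).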

Compound 4, inhibition constant: 1.59 nM
Estimate against measurement, compound 4: 1.6-fold (0.20 log units) below; measured number inside the range.
By their numbers in this assay, from the lowest: compound 2; then compound 4; then compound 1; then compound 3.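

In this assay, 2-chloro-4,6-difluorophenyl in place of 2,6-difluoro-4-methoxyphenyl on a saturated chain carbon bound to an amide-type nitrogen in a ring gives a 4.0-fold higher number from compound 2 to compound 4 (0.60 log units; beyond the scatter), a modest loss, so a ring without a methoxy group can still hold compound 4 at 1.59 nM. The earlier 13-fold higher number from compound 1 to compound 3 (1.10 log units; beyond the scatter) showed only the large loss on removing every ring substituent; this step shows that a substituted ring at this place can carry chlorine, with a modest loss. No measurement on hand explains the size of this step.

The exchange removes methoxy and introduces chlorine in one step, so the share of each in the loss stays unresolved. As far as these compounds go, whether this position accepts an amine or a carboxylic acid on the ring, or a longer chain in place of the benzyl link, also remains open.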